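Cyclopentyl in place of phenyl on the shared core

This account rests on a few compounds, and the source may have more. Where it says the series, first, only, none or still open, it means among the compounds named here.

Of the compounds shown here, two built on the same core have been measured in an assay on HEK293 cells for displacement of a labelled ligand from adenosine receptor A2b (Homo sapiens), with a stated time of 30 min, tested at 1 uM; on this read-out lower numbers stand for less inhibition and higher numbers for more inhibition at the one concentration tested (going by the name of the read-out). Compound 1 `CC1=C(C(=O)OC(C)C)[C@H](c2ccco2)N/C(=N/C#N)N1` carries a furyl group on the saturated ring carbon, and in this assay compound 1 gives 23%. Compound 2 `CC1=C(C(=O)OC(C)C)C(c2ccccc2)N/C(=N/C#N)N1` carries a phenyl group at that position, and in this assay compound 2 gives 32%. On these two numbers compound 2 stands highest, yet its nearest neighbour, compound 1, sits only a little lower, a gap that falls within the usual scatter of repeated measurements, so the two cannot be told apart with confidence.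

Compound 3 `CC1=C(C(=O)OC(C)C)C(C2CCCC2)N/C(=N/C#N)N1` has not yet been measured. It differs from compound 2 in one place: cyclopentyl in place of phenyl on a saturated ring carbon. Within the data shown here, no step between measured compounds exists to lean on for this kind of change, so the expectation rests on the two values alone. The step of a number 7 percentage points lower from compound 2 to compound 3 (within the scatter) is expected to be small, most likely not beyond the scatter, with a slight downward lean. Compound 3 is therefore expected to give about 25% in this assay, with a range from 5% to 45%.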

Compound 3, a percentage reported as inhibition, at one concentration (the size of the read-out at that concentration, not a potency): 11%
Compound 3: the middle estimate sits 14 percentage points above what was measured; measured number inside the range.
By their numbers in this assay, from the lowest: compound 3; then compounds 1 and 2 (each within the scatter of the next).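

In this assay, the change from phenyl to cyclopentyl on the saturated ring carbon is a number 21 percentage points lower from compound 2 to compound 3 (beyond the scatter) and is the only step shown at this position that lies beyond the scatter, whereas the values for the furyl and phenyl compounds could not be told apart. This shows that the position is not indifferent to the group it carries: a six-membered aromatic ring of carbon gives way to a five-membered non-aromatic ring of carbon, with no hydrogen-bond donors or acceptors and no net charge on either group, and the inhibition at the one concentration tested drops. The data offer no measurement that accounts for this drop.

From the compounds shown here alone, whether the lower number goes with the loss of the aromatic ring or with the change in ring size remains open, and a cyclohexyl group on the same carbon would separate these two readings. Going by these compounds, it is also open how this position would respond to an amine or a longer carbon chain, and whether a change here would read the same with a group other than isopropoxycarbonyl on the neighbouring ring atom.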